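Working notes: amine change at the chain end

This account rests on a few compounds, and the source may have more. Where it says the series, first, only, none or still open, it means among the compounds named here.

Measured compounds:
compound 1 `COc1cc2c(Oc3c(F)cc(NC(=S)NN4C(=O)CSC4c4c(F)cccc4F)cc3F)ccnc2cc1OCCCN1CCCC1` gives 410 nM in a functional assay on HT-29 cells (Homo sapiens) for antiproliferative activity, read by MTT assay, with a stated time of 72 h; a higher number here means a weaker inhibitor, a lower number a stronger inhibitor
compound 2 `CCN1CCN(CCCOc2cc3nccc(Oc4c(F)cc(NC(=O)NN5C(=O)CSC5c5c(F)cccc5F)cc4F)c3cc2OC)CC1` gives 73 nM in this assay

Compound 2 stands at the lower of the two numbers; the gap to compound 1 lies beyond the scatter. Compound 1 differs from compound 2 in more than one place, so no single step can be read from that pair. Compound 3 `COc1cc2c(Oc3c(F)cc(NC(=O)NN4C(=O)CSC4c4c(F)cccc4F)cc3F)ccnc2cc1OCCCN1C[C@H]2CCCC[C@H]2C1` carries a group of 9 heavy atoms (8 carbon, 1 nitrogen; one five-membered non-aromatic ring with 1 hetero atom, one six-membered non-aromatic ring of carbon only) in place of a group of 8 heavy atoms (6 carbon, 2 nitrogen; one six-membered non-aromatic ring with 2 hetero atoms), on a saturated chain carbon, three bonds along the chain from an oxygen on an aromatic ring. For the measured compounds named here, no measured pair isolates this change, so only a modest step in this assay is expected, possibly none beyond the scatter. The expected step is a 1.2-fold higher number from compound 2 to compound 3 (0.09 log units; within the scatter). Compound 3 is estimated at 90 nM, within 30 nM to 300 nM.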

Compound 3, half-maximal inhibitory concentration: 470 nM
Estimate against measurement, compound 3: 5.2-fold (0.72 log units) below; measured number above the stated range.
By their numbers in this assay, from the lowest: compound 2; then compounds 1 and 3 (each within the scatter of the next).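

In this assay, the amine at the chain end matters: on a saturated chain carbon, three bonds along the chain from an oxygen on an aromatic ring, replacing 4-ethylpiperazin-1-yl with the group holding one five-membered non-aromatic ring and one six-membered carbon ring gives a 6.4-fold higher number from compound 2 to compound 3 (0.81 log units; beyond the scatter) at an otherwise unchanged structure. For the compounds shown here, this is the first single-place comparison, and it favours 4-ethylpiperazin-1-yl over the entering group. No measurement available here accounts for the step.

Open, on these data alone, is where morpholine or 4-methylpiperazin-1-yl at the same chain end would fall relative to compound 2 and compound 3.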